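This account rests on a few compounds, and the source may have more. Where it says the series, first, only, none or still open, it means among the compounds named here.

Working notes on the series. Compound 3 `O=C(COc1cccc2ccccc12)N/N=C/c1ccccc1Cl` carries a 2-chlorophenyl on the carbon with a double bond to nitrogen. Among the compounds with values here, in a physicochemical assay for lipophilicity, measured as octanol-water partition (on this read-out lower numbers stand for lower lipophilicity and higher numbers for higher lipophilicity), compound 3 gives 4.54, the highest of the three numbers so far. Compound 1 `C/C(=N\NC(=O)COc1cccc2ccccc12)c1ccc(C#N)cc1Br` gives 3.61 in this assay, which stands below compound 3 beyond the scatter, and compound 2 `C/C(=N\NC(=O)COc1cccc2ccccc12)c1ccc([N+](=O)[O-])cc1` gives 3.37, the furthest below compound 3, again beyond the scatter. Within the data shown here, the one measured step, a number 0.24 log units lower from compound 1 to compound 2 (within the scatter), swaps the aryl group at the same place as the change examined here, so it bears on it, though the groups involved are different.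

Compound 4 `CSc1ccc(/C=N/NC(=O)COc2cccc3ccccc23)cc1` differs from compound 3 by 4-(methylsulfanyl)phenyl in place of 2-chlorophenyl on a carbon with a double bond to nitrogen. Both the group that leaves and the group that enters are single six-membered aromatic rings of carbon only. Among the measured compounds shown here, the only comparable step, a number 0.24 log units lower from compound 1 to compound 2 (within the scatter), stayed within the scatter; no measured pair contains a methylsulfanyl group, so nothing directly informs its contribution. A step of a number 0.14 log units lower from compound 3 to compound 4 (within the scatter) is therefore expected in this assay, small and probably not beyond the scatter, with the direction uncertain. For compound 4 the estimate in this assay is 4.4, with a range from 3.9 to 4.9.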

Compound 4, partition coefficient: 4.11
Beside the measured number, compound 4's estimate is 0.29 log units above it, and the stated range covers the measured number.
By their numbers in this assay, from the lowest: compounds 2 and 1 (each within the scatter of the next); then compound 4; then compound 3.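

Within the data shown here, the change of 2-chlorophenyl to 4-(methylsulfanyl)phenyl on a carbon with a double bond to nitrogen gives a number 0.43 log units lower from compound 3 to compound 4 (beyond the scatter), the first step at this place to stand clear of the scatter, whereas the earlier swap of aryl groups gave a number 0.24 log units lower from compound 1 to compound 2 (within the scatter). In this assay, the aryl group at this place can therefore shift the number measurably, although this rests on a single pair in which the leaving chlorine, the entering methylsulfanyl group and the place of substitution on the ring all change together. Nothing available explains the size or direction of this step.

The pair does not show how much of the step goes with the loss of the 2-chloro substituent and how much with the gain of the 4-(methylsulfanyl) substituent, nor whether the same swap on the core of compound 1 would give a similar step. Also open, as far as these compounds go, is where an unsubstituted phenyl, or a phenyl carrying an amine or a carboxylic acid, would fall at this place in this assay.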